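Swapping the Group on the Amide-Type Nitrogen

The compounds below may be only part of what the source reports. "The series", "measured", "known", "first", "only" and "open" are said of these compounds alone.

Of the compounds shown here, two have so far been measured in a functional assay on HL-60 cells (Homo sapiens) for antiproliferative activity, read by sulforhodamine B assay, with a stated time of 72 h; a lower number here means a stronger inhibitor, a higher number a weaker inhibitor. Compound 1 `NC(=S)N/N=C/c1cc2ccccc2s1` gives only a limit of the assay, > 100000 nM. Compound 2 `Cc1ccccc1NC(=S)N/N=C/c1ccc2ccccc2n1` gives 73200 nM in this assay, which is the only actual number among the results shown. The other result is the limit of > 100000 nM in this assay, at which 1 of the 2 values shown sits, so compound 2 cannot be placed above or below a neighbour and serves only as the single firm reference point. Compound 3 `COc1ccc(NC(=S)N/N=C/c2ccc3ccccc3n2)cc1` has not yet been measured in this assay. It differs from compound 2 in one place: 4-methoxyphenyl in place of 2-methylphenyl on an amide-type nitrogen. Going by the values given here, no step between two measured compounds is available to show how such a change on the amide-type nitrogen shifts the result, so no direction can be read from the data. The change is expected to move the value little, with an estimated step of a 1.1-fold higher number from compound 2 to compound 3 (0.04 log units; within the scatter). Compound 3 is therefore expected to give about 80000 nM in this assay, estimated to fall between 25000 nM and 250000 nM, with a real chance that only a limit is reported.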

Compound 3, half-maximal inhibitory concentration: 43800 nM
Compound 3: the middle estimate sits 1.8-fold (0.26 log units) above what was measured, and the stated range covers the measured number.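

Going by these compounds alone, this is the first step between two measured compounds at this amide-type nitrogen, and in this assay putting 4-methoxyphenyl in place of 2-methylphenyl gives a 1.7-fold lower number from compound 2 to compound 3 (0.22 log units; within the scatter). That step lies within the usual scatter of repeated measurements, so the two compounds cannot be ranked, and this swap of one substituted phenyl group for another shows no real difference at this position. The entering group carries an oxygen and a hydrogen-bond acceptor that the leaving group lacks, yet this single pair gives no sign that either one matters for the result.

Going by these compounds, it remains open whether a group of a quite different kind on this nitrogen, such as a carboxylic acid, an amine or a longer alkyl chain, would give a step beyond the scatter, since one pair of phenyl groups cannot speak for other replacements. Within the data shown here, compound 1 differs from the other compounds in more than one place and its result is only a limit of the assay, so it adds no step to this comparison: the limit of > 100000 nM in this assay, at which 1 of the 3 values shown sits.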